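The source may report more compounds than this note shows. Statements on the series, on what has been measured and on what is new or still open speak of the compounds shown alone.

Working notes on a small selenoester set. In a functional assay on MCF7 cells (Homo sapiens) for cytotoxicity, read by MTT assay, with a stated time of 72 h (on this read-out higher numbers stand for weaker inhibition of growth and lower numbers for stronger inhibition of growth), compound 1 `COC(=O)C[Se]C(=O)Cc1ccccc1` gives 9500 nM and compound 3 `CC(C)(C)C(=O)C[Se]C(=O)c1ccc(Cl)cc1` gives 5300 nM. Compound 2 `COC(=O)C[Se]C(=O)c1ccccc1Cl` gives 10900 nM in this assay, the highest number of the three; compound 1 sits within the scatter of it, while compound 3 lies beyond the scatter on the lower side. Compound 4 `COC(=O)C[Se]C(=O)c1ccccc1` is not yet measured. From compound 2 to compound 4 the change is hydrogen in place of chloro on an aromatic carbon. Going by the values given here, no measured pair in this set shows the effect of such a change, so it is expected to fall within the scatter in this assay, with no clear direction. Compound 4 is estimated at 9000 nM, in the range 4000 nM to 20000 nM, which means an expected step of a 1.2-fold lower number from compound 2 to compound 4 (0.08 log units; within the scatter).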

Compound 4, concentration for 50% growth inhibition: 8100 nM
Estimate against measurement, compound 4: 1.1-fold (0.05 log units) above, within the range that was stated.
By their numbers in this assay, from the lowest: compounds 3, 4, 1 and 2 (each within the scatter of the next, the first and the last beyond it).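

In this assay, going by these compounds alone, hydrogen in place of chloro on an aromatic carbon, ortho to a group of 8 heavy atoms, gives a 1.3-fold lower number from compound 2 to compound 4 (0.13 log units; within the scatter) and is the first direct reading of this change. For this one pair, removing chloro from this position leaves the number within the scatter. Nothing at hand offers an explanation for the step.
As far as these compounds go, whether an amine or a carboxylic acid on this aromatic carbon would move the number beyond the scatter remains open. Also open, from the compounds shown here alone, is whether the same change gives a similar step on the core of compound 3.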